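A few compounds are considered here, and "the series" means these few. Any claim that something is new, unique, unknown or untested is made for them only; others in the source may bear on it.

Measured so far: compound 1 `CCc1ccccc1N(CC(=O)NCc1cccc(Cl)c1)S(=O)(=O)c1ccc(C)cc1` with 1410 nM; compound 2 `CCc1ccccc1N(CC(=O)NCc1ccc(C(F)(F)F)cc1)S(=O)(=O)c1ccc(C)cc1` with 209 nM.

Both compounds were tested in a functional assay on CHO-K1 cells for antagonist activity at prostaglandin E2 receptor EP1 subtype (Homo sapiens), read by FLIPR and calcium flux; on this read-out lower numbers stand for stronger inhibition and higher numbers for weaker inhibition. For the measured compounds named here, compound 2 gives the lowest of the two numbers; the only neighbour is compound 1, and the step between them, a 6.7-fold lower number from compound 1 to compound 2 (0.83 log units; beyond the scatter), is beyond the scatter, so the group on the saturated chain carbon bound to the amide-type nitrogen clearly matters here.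

Compound 3 `CCc1ccccc1N(CC(=O)NCc1ccccc1OC)S(=O)(=O)c1ccc(C)cc1` has not yet been measured. Its change from compound 2 is 2-methoxyphenyl in place of 4-(trifluoromethyl)phenyl on a saturated chain carbon bound to an amide-type nitrogen: a smaller group, carrying one hydrogen-bond acceptor where none stood before, and placed differently on the ring. Going by the values given here, only one measured step bears on this position, the one from compound 1 to compound 2, and it shows that a different arrangement of the ring substituent can shift the number by a modest amount. With no measurement of a methoxy group of this kind, the expectation is that compound 3 moves back toward compound 1, with a step of a 4.3-fold higher number from compound 2 to compound 3 (0.63 log units; beyond the scatter) in this assay expected. Compound 3 is estimated at 900 nM, within 250 nM to 3500 nM.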

Compound 3, inhibition constant: 1070 nM
Compound 3: the middle estimate sits 1.2-fold (0.08 log units) below what was measured; low and high end bracket the measured number.
By their numbers in this assay, from the lowest: compound 2; then compounds 3 and 1 (each within the scatter of the next).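

Replacing 4-(trifluoromethyl)phenyl with 2-methoxyphenyl on the saturated chain carbon bound to the amide-type nitrogen gives a 5.1-fold higher number from compound 2 to compound 3 (0.71 log units; beyond the scatter), so a second, quite different ring group also falls short of compound 2 in this assay. Set against 3-chlorophenyl, the same 2-methoxyphenyl group gives a 1.3-fold lower number from compound 1 to compound 3 (0.12 log units; within the scatter): compound 1 and compound 3 cannot be told apart, even though they carry different substituents, and among these three compounds only the 4-(trifluoromethyl)phenyl group of compound 2 stands out. No measurement at hand offers a reason for this pattern.

As far as these compounds go, each of these steps changes the substituent and its place on the ring together, so it stays open whether the lower number of compound 2 belongs to the trifluoromethyl group itself or to where it sits. Also open, from the compounds shown here alone, is how this position would respond to a plain phenyl ring with no substituent, or to a ring carrying a nitrile, an amine or a carboxylic acid.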